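Ring exchange on the double-bonded carbon: compound 4

The source may hold more compounds than are shown below. What is called first, only, known or untested is meant among the compounds shown, and "the series" means these compounds.

Compound 1 `CN(C)CCn1cnnc1-c1cc(Oc2ccc(NC(=O)N/N=C/c3ccc(Cl)cc3Cl)cc2F)ccn1` gives 390 nM in a functional assay on HT-29 cells (Homo sapiens) for cytotoxicity, read by MTT assay, with a stated time of 72 h; a higher number here means a weaker inhibitor, a lower number a stronger inhibitor. Among the three measured compounds it holds the lowest number. Compound 2 `CN(C)CCn1cnnc1-c1cc(Oc2ccc(NC(=O)N/N=C/c3ccc(O)c(Br)c3)cc2F)ccn1` gives 450 nM, a difference of a 1.2-fold higher number from compound 1 to compound 2 (0.06 log units; within the scatter), and compound 3 `CN(C)CCn1cnnc1-c1cc(Oc2ccc(NC(=O)N/N=C/c3ccccc3)cc2F)ccn1` gives 1120 nM, a difference of a 2.9-fold higher number from compound 1 to compound 3 (0.46 log units; beyond the scatter). Between compound 2 and compound 3 the step is a 2.5-fold higher number from compound 2 to compound 3 (0.40 log units; beyond the scatter).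

Compound 4 `CN(C)CCn1cnnc1-c1cc(Oc2ccc(NC(=O)N/N=C/c3ccc(F)cc3F)cc2F)ccn1` differs from compound 1 only in the aryl group on the carbon with a double bond to nitrogen: 2,4-difluorophenyl in place of 2,4-dichlorophenyl on a carbon with a double bond to nitrogen.

Within the data shown here, the steps that bear on this change are those in which the same aryl group was exchanged: a 2.9-fold higher number from compound 1 to compound 3 (0.46 log units; beyond the scatter), where a plain phenyl replaced the 2,4-dichlorophenyl, and a 2.5-fold higher number from compound 2 to compound 3 (0.40 log units; beyond the scatter). Both show that going to the bare phenyl raises the number by a modest amount, whereas exchanging one substituted ring for another, a 1.2-fold higher number from compound 1 to compound 2 (0.06 log units; within the scatter), stayed within the scatter. Compound 4 keeps a substituted ring, so its number is expected to sit between the substituted and the unsubstituted cases, nearer to compound 1, and a step of a 1.5-fold higher number from compound 1 to compound 4 (0.19 log units; within the scatter) is expected. The estimate for compound 4 is 600 nM, with a range from 300 nM to 1300 nM.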

Compound 4, half-maximal inhibitory concentration: 960 nM
Beside the measured number, compound 4's estimate is 1.6-fold (0.20 log units) below it; the range from low to high includes it.
By their numbers in this assay, from the lowest: compounds 1 and 2 (each within the scatter of the next); then compounds 4 and 3 (each within the scatter of the next).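

In this assay, the halogen on the 2,4-disubstituted ring matters at this position: 2,4-difluorophenyl in place of 2,4-dichlorophenyl gives a step beyond the scatter (a 2.5-fold higher number from compound 1 to compound 4 (0.39 log units; beyond the scatter)). Compound 4 cannot be told apart from the unsubstituted compound 3 (a 1.2-fold lower number from compound 3 to compound 4 (0.07 log units; within the scatter)), so in this set two ring halogens do not by themselves keep the number near that of compound 1, and compound 4 goes against the reading that the substituted rings of compound 1 and compound 2 had suggested. The step to the other substituted ring is also beyond the scatter (a 2.1-fold higher number from compound 2 to compound 4 (0.33 log units; beyond the scatter)), which means that the agreement between compound 1 and compound 2 does not extend to every substituted ring on the carbon with a double bond to nitrogen.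

The compounds shown leave open whether 2,4-dibromophenyl, or a ring carrying a methoxy group or an amine, would sit with compound 1 and compound 2 or with compound 3 and compound 4. No supporting measurement is available to explain the difference between the chlorine and fluorine compounds.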